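The source may report more compounds than this note shows. Statements on the series, on what has been measured and on what is new or still open speak of the compounds shown alone.

Measured compounds:
Compound 1 `CC1=CC[C@@H]([C@@](C)(O)CCCC(C)(C)NC(=S)N/N=C\c2ccc(C)cc2)CC1` gives > 100000 nM in a functional assay on MCF7 cells (Homo sapiens) for cytotoxicity, read by sulforhodamine B assay (on this read-out lower numbers stand for stronger inhibition of growth and higher numbers for weaker inhibition of growth), which is a limit of the assay and not a number.
Compound 2 `CC1=CC[C@@H]([C@@](C)(O)CCCC(C)(C)NC(=S)N/N=C\c2ccccc2Cl)CC1` gives > 100000 nM in this assay, again a limit and not a number.

Compound 2 thus stands at the limit of this assay, and the step that the two limits leave unreadable from compound 1 to compound 2 cannot be read, as both ends are limits. Compound 3 `CC1=CC[C@@H]([C@@](C)(O)CCCC(C)(C)NC(=S)N/N=C(/C)c2ccccc2)CC1` differs from compound 2 by a group of 9 heavy atoms (8 carbon, 1 nitrogen; one six-membered aromatic ring of carbon only) in place of a group of 9 heavy atoms (7 carbon, 1 nitrogen, 1 chlorine; one six-membered aromatic ring of carbon only), on an amide-type nitrogen. Among the measured compounds shown here, no measured step bears on this change, as the only step recorded is unreadable. Both measured values sit at the limit of > 100000 nM in this assay, at which 2 of the 2 values shown sit, so compound 3 is expected to remain at that limit as well, with no step beyond the scatter readable in either direction. The estimate for compound 3 in this assay is 100000 nM, with a range from 30000 nM to 300000 nM. The step of a number no higher from compound 2 to compound 3 (the limit leaves the size open) is accordingly expected to be none that can be told from the scatter.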

Compound 3, concentration for total growth inhibition: 62900 nM
Beside the measured number, compound 3's estimate is 1.6-fold (0.20 log units) above it; the measured number falls inside the stated range.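

In this assay, compound 3 is the first of the compounds shown to give a number rather than a limit, so the group on the amide-type nitrogen now has a value that later changes at this place can be read against. Going by these compounds, the change itself can be read only as a floor: the record gives an at least 1.5-fold lower number from compound 2 to compound 3 (0.20 log units; that floor lies within the scatter), and also an at least 1.5-fold lower number from compound 1 to compound 3 (0.20 log units; that floor lies within the scatter), so the true size of each step stays open and neither can be told from the scatter. The series still rests mostly on limits, and this single number has no measured neighbour: the limit of > 100000 nM in this assay, at which 2 of the 3 values shown sit.

The compounds shown leave open whether an amine, a carboxylic acid or a longer chain in the group on the amide-type nitrogen would move the number in either direction. They also leave open how any change to the shared core would read.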